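A Fused Bicyclic Swap on a Shared Core

The source may hold more compounds than are shown below. What is called first, only, known or untested is meant among the compounds shown, and "the series" means these compounds.

Compound 1 `Cn1c(=O)c(S(=O)(=O)c2ccc(Cl)cc2)cc2cnc(Nc3cnc4ccccc4c3)nc21`: 15000 nM
Compound 2 `Cc1ccc(S(=O)(=O)c2cc3cnc(Nc4cccc5cccnc45)nc3n(C)c2=O)cc1`: 10000 nM
Compound 3 `Cn1c(=O)c(S(=O)(=O)Nc2ccc(F)cc2F)cc2cnc(Nc3ccc4[nH]ccc4c3)nc21`: 5000 nM

Three compounds built on one shared core have been examined in a functional assay on DU-145 cells (Homo sapiens) for inhibition, read by trypan blue exclusion, with a stated time of 72 h; on this read-out lower numbers stand for stronger inhibition and higher numbers for weaker inhibition. Compound 1 gives the highest of the three numbers; compound 2 sits within the scatter of it, while compound 3 lies beyond the scatter with a lower number. Compound 4 `Cn1c(=O)c(S(=O)(=O)c2ccc(Cl)cc2)cc2cnc(Nc3cnc4[nH]ccc4c3)nc21` has not yet been measured. It differs from compound 1 in one place: a group of 9 heavy atoms (7 carbon, 2 nitrogen; one five-membered aromatic ring with 1 hetero atom, one six-membered aromatic ring with 1 hetero atom) in place of a group of 10 heavy atoms (9 carbon, 1 nitrogen; one six-membered aromatic ring of carbon only, one six-membered aromatic ring with 1 hetero atom), on a nitrogen on an aromatic ring. Among the measured compounds shown here, no measured pair isolates this change, so its effect cannot be read from any step. A modest move toward a lower number is expected for compound 4, a 1.9-fold lower number from compound 1 to compound 4 (0.27 log units; within the scatter), though the step may not exceed the scatter. Compound 4 is therefore estimated at 8000 nM, with a range from 2500 nM to 25000 nM.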

Compound 4, half-maximal inhibitory concentration: 5000 nM
Compound 4: middle estimate off by 1.6-fold (0.20 log units), on the high side; the range from low to high includes it.
By their numbers in this assay, from the lowest: compounds 3, 4, 2 and 1 (each within the scatter of the next, the first and the last beyond it).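

In this assay, the group with a five-membered and a six-membered aromatic ring in place of quinolin-3-yl, on a nitrogen on an aromatic ring, gives a 3.0-fold lower number from compound 1 to compound 4 (0.48 log units; beyond the scatter). Among the compounds shown here, this is the one step at this position that isolates a single change, and it shows that the position responds to this swap beyond the scatter. Nothing measured here accounts for the step.

The compounds shown leave open whether a single ring at this place, such as a plain phenyl or a pyridine, would keep the step. They also leave open whether the same swap would give a similar step with a different group on the sulfonyl.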